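The source may hold more compounds than are shown below. What is called first, only, known or untested is meant among the compounds shown, and "the series" means these compounds.

Compound 1 `COc1ccc(C2=NN(C(=O)C(C)Br)C(c3ccco3)C2)cc1OC` and compound 3 `COc1ccc(C2=NN(C(=O)CNc3ccc(/C(C)=N/O)cc3)C(c3ccco3)C2)cc1OC` share a core whose difference between them is not broken down here. In a functional assay on the whole organism (strain albino) for inhibition, with Rattus norvegicus as the target, read by paw edema, with stated times of 30 min and 1 h, at a dose of 100 mg/kg by the oral route (on this read-out lower numbers stand for less inhibition and higher numbers for more inhibition at the one dose given (going by the name of the read-out)), compound 1 gives 22% and compound 3 gives 38%. Compound 2 `COc1ccc(C2CC(c3ccc(OC)c(OC)c3)=NN2C(=O)C(C)Br)c(OC)c1` arises from compound 1 by 2,4-dimethoxyphenyl in place of furan-2-yl on a saturated ring carbon; in this assay compound 2 gives 58%, so a number 36 percentage points higher from compound 1 to compound 2 (beyond the scatter). Compound 4 `COc1ccc(C2CC(c3ccc(OC)c(OC)c3)=NN2C(=O)CNc2ccc(/C(C)=N/O)cc2)c(OC)c1`, not yet measured, arises from compound 3 by the same kind of change, (2,4-dimethoxyphenyl in place of furan-2-yl on a saturated ring carbon); the surroundings differ in that the place is next to the ring atom that bears a large group rather than a (1-bromoethyl)carbonyl group, and is two ring bonds from the ring atom that bears a 3,4-dimethoxyphenyl group rather than a large group. Because a number 36 percentage points higher from compound 1 to compound 2 (beyond the scatter) was large, and compound 3 starts from 38%, a step of a number 28 percentage points higher from compound 3 to compound 4 (beyond the scatter) is expected in this assay. Compound 4 is estimated at 66%, expected between 46% and 84%.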

Compound 4, a percentage reported as inhibition, in the whole organism at one dose (the size of the read-out at that dose, not a potency): 27%
For compound 4 the middle estimate is 39 percentage points above the measured one; the whole stated range lies above it.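

In this assay, 2,4-dimethoxyphenyl in place of furan-2-yl does not carry over from one core to the other, in either size or direction: the same change on two cores in this assay, a number 36 percentage points higher (beyond the scatter) from compound 1 to compound 2 and a number 11 percentage points lower (beyond the scatter) from compound 3 to compound 4, 47 percentage points apart, beyond the scatter of two such steps

The step on the second core is a number 11 percentage points lower from compound 3 to compound 4 (beyond the scatter), and with 2,4-dimethoxyphenyl held, changing the group on the carbonyl carbon gives a number 31 percentage points lower from compound 2 to compound 4 (beyond the scatter). These two pairs show that the outcome of this change depends on the core, but not which part of the core is responsible, and they set no rule for the wider series.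

Going by these compounds, it remains open whether a phenyl or thiophene group on the saturated ring carbon would follow compound 2 or compound 4. On these data alone, a dimethylamino group on the carbonyl carbon also remains open.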